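Methyl for methoxy on a selenocyanate carbamate series

The source may report more compounds than this note shows. Statements on the series, on what has been measured and on what is new or still open speak of the compounds shown alone.

Measured so far:
compound 1 `COc1ccc(OC(=O)Nc2ccc([Se]C#N)cc2)cc1`: 4500 nM
compound 2 `C=CCOC(=O)Nc1ccc([Se]C#N)cc1`: 5000 nM

In an ADME assay on 184B5 cells (Homo sapiens) for cytotoxicity, read by MTT assay, with a stated time of 72 h (on this read-out lower numbers stand for stronger inhibition of growth and higher numbers for weaker inhibition of growth), compound 1 gives 4500 nM. Compound 2, which carries an allyl carbamate in place of the aryl carbamate, gives 5000 nM in this assay. Compound 1 has the lowest of the two numbers, yet its gap to compound 2 lies within the scatter, so the two values cannot be told apart.

The account now turns to compound 3 `Cc1ccc(OC(=O)Nc2ccc([Se]C#N)cc2)cc1`, which is not yet measured in this assay. It differs from compound 1 in one place: methyl in place of methoxy on an aromatic carbon. For the measured compounds named here, no step between measured compounds of this kind is known, and both measured values in this assay sit close together, so no direction for this step can be drawn from the data.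

Accordingly, the expected step from compound 1 to compound 3 in this assay is a 1.1-fold higher number from compound 1 to compound 3 (0.05 log units; within the scatter), that is, none beyond the scatter. The estimated value for compound 3 in this assay is 5000 nM, with a range from 2500 nM to 10000 nM.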

Compound 3, concentration for 50% growth inhibition: 4400 nM
Compound 3: middle estimate off by 1.1-fold (0.06 log units), on the high side; the measured number falls inside the stated range.
By their numbers in this assay, from the lowest: compounds 3, 1 and 2 (each within the scatter of the next).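

In this assay, for the compounds shown here, the swap of methoxy for methyl on an aromatic carbon para to a large group gives a 1.0-fold lower number from compound 1 to compound 3 (0.01 log units; within the scatter) and is the first step between measured compounds that differ in one place. At this position, then, removing the oxygen and its one hydrogen-bond acceptor leaves the number within the scatter, something the earlier pair could not show, since compound 1 and compound 2 differ in the whole group on the carbamate and not in a single substituent on the ring. Nothing measured here accounts for the two groups reading alike, and no outside evidence bears on this result.

From the compounds shown here alone, whether this position accepts groups of a different kind, such as an amine, a carboxylic acid or a longer chain, remains open, and one step between two small groups cannot mark the limits of what fits there. Going by these compounds, it is also open whether the same swap of methoxy for methyl would read alike at another place on this ring, or on a compound with a different carbamate group, such as the allyl carbamate of compound 2.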